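Benzyl group swap and cytotoxicity: compound 3 to compound 4

This account rests on a few compounds, and the source may have more. Where it says the series, first, only, none or still open, it means among the compounds named here.

Compound 1 `CCOC(=O)c1cnc(N2CCN(Cc3ccc(C(F)(F)F)cc3)CC2)nc1Oc1c(C)cc(-c2ccc(C#N)cc2)cc1C` reaches only the limit of an ADME assay on MT4 cells (Homo sapiens) for cytotoxicity, read by MTT assay, with a stated time of 4 days (on this read-out lower numbers stand for higher toxicity in this test and higher numbers for lower toxicity in this test), giving > 125000 nM. Compound 2 `CCOC(=O)c1cnc(N2CCN(Cc3ccc(C(=O)OC)cc3)CC2)nc1Oc1c(C)cc(-c2ccc(C#N)cc2)cc1C` likewise gives only the limit > 125000 nM in this assay. For the measured compounds named here, compound 3 `CCOC(=O)c1cnc(N2CCN(Cc3cccc(C(N)=O)c3)CC2)nc1Oc1c(C)cc(-c2ccc(C#N)cc2)cc1C` is the one member with a number, 14800 nM, and so stands lowest among the values shown. Compound 4 `CCOC(=O)c1cnc(N2CCN(Cc3ccc(S(C)(=O)=O)cc3)CC2)nc1Oc1c(C)cc(-c2ccc(C#N)cc2)cc1C` carries the change (4-(methylsulfonyl)phenyl in place of 3-carbamoylphenyl on a saturated chain carbon bound to an amine nitrogen in a ring). The measured steps that bear on it run the other way: an at least 8.4-fold lower number from compound 1 to compound 3 (0.92 log units; beyond the scatter) and an at least 8.4-fold lower number from compound 2 to compound 3 (0.92 log units; beyond the scatter), both reckoned against (the limit of > 125000 nM in this assay, at which 2 of the 3 values shown sit). Compound 4, with a 4-(methylsulfonyl)benzyl, is closer to compounds 1 and 2 than to compound 3 in this part, so a higher number is expected for compound 4, by a 5.4-fold higher number from compound 3 to compound 4 (0.73 log units; beyond the scatter), around 80000 nM (range 20000 nM to 150000 nM), with the limit itself quite possible.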

Compound 4, half-maximal cytotoxic concentration: > 125000 nM
Compound 4: a limit, no number; the forecaster's own chance of this, stated with the estimate: 55%; middle value at least 1.5-fold (0.19 log units) away from the limit.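

Exchanging 3-carbamoylphenyl for 4-(methylsulfonyl)phenyl gives an at least 8.4-fold higher number from compound 3 to compound 4 (0.92 log units; beyond the scatter) in this assay and this step rests on a limit for compound 4, not a number. For the compounds shown here, compound 3 remains the only member with a number, and the steps among compounds 1, 2 and 4 cannot be read: the limit of > 125000 nM in this assay, at which 3 of the 4 values shown sit.

The change from 3-carbamoylbenzyl to 4-(methylsulfonyl)benzyl alters both the group and where it sits, so the two effects cannot be separated. On these data alone, what a carboxylic acid or an amine on that benzyl group would give in this assay stays open.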